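The source may report more compounds than this note shows. Statements on the series, on what has been measured and on what is new or still open speak of the compounds shown alone.

Measured compounds: compound 1 `COc1ccc(Cc2c(C)[nH]n(-c3nc4ccccc4[nH]3)c2=O)cc1` with 630 nM; compound 2 `Cc1[nH]n(-c2nc3ccccc3[nH]2)c(=O)c1Cc1ccc(-c2ccccc2)cc1` with 720 nM.

In an assay on isolated protein for inhibition of alpha-ketoglutarate-dependent dioxygenase alkB homolog 3 (Homo sapiens), read by polymerase chain reaction, with a stated time of 1 h (on this read-out lower numbers stand for stronger inhibition and higher numbers for weaker inhibition), compound 2 stands as the higher of the two numbers, though its nearest neighbour compound 1 sits within the scatter of it, so no order between the two can be read. For the measured compounds named here, the only measured step, a 1.1-fold higher number from compound 1 to compound 2 (0.06 log units; within the scatter), concerns the group on the benzyl ring and is itself within the scatter.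

Compound 3 `Cc1ccc2[nH]c(-n3[nH]c(C)c(Cc4ccc(-c5ccccc5)cc4)c3=O)nc2c1` differs from compound 2 by methyl in place of hydrogen on an aromatic carbon. Going by the values given here, no measured step touches this part of the shared core, so nothing in the numbers so far speaks for a shift in either direction; the one step available, small as it is, gives no ground to expect more than scatter here either. Compound 3 is therefore expected to give 700 nM in this assay, in the range 300 nM to 1600 nM, which means an expected step of a 1.0-fold lower number from compound 2 to compound 3 (0.01 log units; within the scatter).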

Compound 3, half-maximal inhibitory concentration: 5300 nM
The estimate for compound 3 lay 7.6-fold (0.88 log units) below the measured number; measured number above the stated range.
By their numbers in this assay, from the lowest: compounds 1 and 2 (each within the scatter of the next); then compound 3.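

In this assay, for the compounds shown here, the change from 1H-benzimidazol-2-yl to 5-methyl-1H-benzimidazol-2-yl gives a 7.4-fold higher number from compound 2 to compound 3 (0.87 log units; beyond the scatter), the first step beyond the scatter. This aromatic carbon of the six-membered ring therefore responds to a single added methyl, whereas the exchange of methoxy for phenyl on the benzyl ring gave only a 1.1-fold higher number from compound 1 to compound 2 (0.06 log units; within the scatter) and no readable change. Nothing at hand explains the loss of inhibition.

Still open, going by these compounds, is whether the loss is particular to methyl or extends to other groups on this carbon, such as fluorine, an amine or a carboxylic acid. Also open, on these data alone, is whether the same methyl produces a similar step with methoxy in place of phenyl on the benzyl ring, as in compound 1.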